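The source may hold more compounds than are shown below. What is called first, only, known or untested is meant among the compounds shown, and "the series" means these compounds.

Compound 1 `O=S(=O)(c1cccc(F)c1)c1cnc2c(F)cccc2c1-c1cccc(Cl)c1` gives 0.56 mL/min in an ADME assay on microsomes from liver (Homo sapiens) for metabolic stability, tested at 2.5 uM; a higher number here means faster removal of the compound, a lower number slower removal. Compound 2 `COc1ccc(-c2c(S(=O)(=O)c3ccc(F)cc3)cnc3c(F)cccc23)cc1` gives 2.41 mL/min in this assay. Compound 3 `COc1ccc(-c2c(S(=O)(=O)c3cccc(F)c3)cnc3c(F)cccc23)cc1` gives 2.48 mL/min in this assay.

Compound 4 `O=S(=O)(c1ccc(F)cc1)c1cnc2c(F)cccc2c1-c1cccc(Cl)c1` has not yet been measured in this assay. It differs from compound 2 by 3-chlorophenyl in place of 4-methoxyphenyl on an aromatic carbon. The same change has already been measured once: from compound 3 to compound 1 it is 3-chlorophenyl in place of 4-methoxyphenyl on an aromatic carbon, and it gave a 4.4-fold lower number from compound 3 to compound 1 (0.65 log units; beyond the scatter). The cores of compound 2 and compound 3 differ by 4-fluorophenyl in place of 3-fluorophenyl on a sulfonyl sulfur, a change that gave a 1.0-fold higher number from compound 2 to compound 3 (0.01 log units; within the scatter), so the two starting points stand very close. The step expected for compound 4, a 4.4-fold lower number from compound 2 to compound 4 (0.64 log units; beyond the scatter), is estimated to match the earlier one, resting on that single measured instance and on compound 2 giving 2.41 mL/min. Compound 4 is thus expected near 0.55 mL/min, with a likely range from 0.3 mL/min to 1 mL/min.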

Compound 4, intrinsic clearance in a liver preparation (reported as CLH), per the amount of preparation that the assay uses: 1.21 mL/min
For compound 4 the middle estimate is 2.2-fold (0.34 log units) below the measured one; measured number outside the range, above it.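

In this assay, 3-chlorophenyl in place of 4-methoxyphenyl gives a 2.0-fold lower number from compound 2 to compound 4 (0.30 log units; within the scatter), and the two cores cannot be told apart for this change: the same change on two cores in this assay, a 4.4-fold lower number (0.65 log units; beyond the scatter) from compound 3 to compound 1 and a 2.0-fold lower number (0.30 log units; within the scatter) from compound 2 to compound 4, 2.2-fold (0.35 log units) apart, within the scatter of two such steps. Likewise, 4-fluorophenyl in place of 3-fluorophenyl gives a 2.2-fold higher number from compound 1 to compound 4 (0.33 log units; beyond the scatter), and this step cannot be told apart from its earlier counterpart: the same change on two cores in this assay, a 1.0-fold higher number (0.01 log units; within the scatter) from compound 2 to compound 3 and a 2.2-fold lower number (0.33 log units; beyond the scatter) from compound 4 to compound 1, 2.2-fold (0.35 log units) apart, within the scatter of two such steps. Each change therefore carries across these two cores as far as the scatter allows, but two readings per change do not show that the steps are equal in size or that they would hold on any other core.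

The compounds shown leave open how a group other than a substituted phenyl, such as an amine or a carboxylic acid, would behave in the place of the 3-chlorophenyl on the shared core.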